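The compounds below may be only part of what the source reports. "The series", "measured", "known", "first", "only" and "open" are said of these compounds alone.

Compound 3 `CC1=C(C(=O)Nc2ccc([N+](=O)[O-])cc2)C(c2ccc(Br)cc2)N=C(SCc2ccccc2Cl)N1` gives 13.9% in a functional assay on the whole organism (artery, strain albino) with Rattus norvegicus as the target, with a stated time of 360 min, at a dose of 10 mg/kg by the oral route (on this read-out lower numbers stand for less inhibition and higher numbers for more inhibition at the one dose given (going by the name of the read-out)), the lowest of the three numbers shown. Compound 2 `CC1=C(C(=O)Nc2ccc([N+](=O)[O-])cc2)C(c2ccc(Br)cc2)N=C(SCc2ccccc2)N1` gives 37.6%, and compound 1 `COc1ccc(C2N=C(SCc3cccc(Cl)c3)NC(C)=C2C(=O)Nc2ccc(Br)cc2)cc1` gives 39.7%. For the measured compounds named here, the only single-change step among them is a number 23.7 percentage points lower from compound 2 to compound 3 (beyond the scatter). Compound 4 `CC1=C(C(=O)Nc2ccc([N+](=O)[O-])cc2)C(c2ccc(Br)cc2)N=C(SCc2cccc(Cl)c2)N1` differs from compound 3 by 3-chlorophenyl in place of 2-chlorophenyl on a saturated chain carbon bound to a sulfur. Going by the values given here, no measured step covers this shift of the chlorine directly; compound 1 carries the same 3-chlorobenzyl group as compound 4 but differs from it in two further places, so only its value can be noted. A modest rise is expected because a number 23.7 percentage points lower from compound 2 to compound 3 (beyond the scatter) lowered the number and the 3-chlorophenyl group of compound 1 sits on a compound with 39.7%; the expected step is a number 16.1 percentage points higher from compound 3 to compound 4 (beyond the scatter). Compound 4 is therefore estimated at 30%, between 12% and 48%.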

Compound 4, a percentage reported as inhibition, in the whole organism at one dose (the size of the read-out at that dose, not a potency): 7.2%
Estimate against measurement, compound 4: 22.8 percentage points above, outside the stated range (below it).
By their numbers in this assay, from the lowest: compounds 4 and 3 (each within the scatter of the next); then compounds 2 and 1 (each within the scatter of the next).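

In this assay, swapping 2-chlorophenyl for 3-chlorophenyl on a saturated chain carbon bound to a sulfur gives a number 6.7 percentage points lower from compound 3 to compound 4 (within the scatter) and so shows no readable effect of moving the chlorine. Chloro in place of hydrogen still costs inhibition in the new placement, with a number 30.4 percentage points lower from compound 2 to compound 4 (beyond the scatter) and thus a drop in both compound 3 and compound 4. Nothing available explains this drop. On these data alone, whether a fluoro, a methyl, an amine or a carboxylic acid in place of the chlorine would also lower the number stays open.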